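Swapping a Cyclohexyl for a Dibromobutenyl Chain

The source may report more compounds than this note shows. Statements on the series, on what has been measured and on what is new or still open speak of the compounds shown alone.

Going by the values given here, compound 2 `C[C@@H]1O[C@H](C2CCCCC2)C([Si](C)(C)C)=C(Cl)[C@H]1C` is one of two compounds measured in a functional assay on SW1573 cells (Homo sapiens) for antiproliferative activity; a lower number here means a stronger inhibitor of growth, a higher number a weaker inhibitor of growth. Compound 2 gives 20000 nM, the higher of the two numbers, and the nearest neighbour, compound 1 `C[C@H]1CC(Cl)=C([Si](C)(C)C)[C@@H](C2CCCCC2)O1`, gives 16000 nM. Among the compounds with values here, the only measured step, a 1.3-fold higher number from compound 1 to compound 2 (0.10 log units; within the scatter), comes from a methyl in place of hydrogen on a saturated ring carbon and is too small to count as a real change. Compound 3 `C[C@@H]1O[C@H](CCC=C(Br)Br)C([Si](C)(C)C)=C(Cl)[C@H]1C` has not yet been measured. It differs from compound 2 in one respect: 4,4-dibromobut-3-en-1-yl in place of cyclohexyl on a saturated ring carbon. Within the data shown here, no measured step concerns an exchange of this kind, since the one step known swaps a different group elsewhere on the shared core, so there is no direct guide to the size or direction of the effect. Compound 3 is therefore expected to show a step of no change at the digits printed from compound 2 to compound 3 (within the scatter) that stays within the scatter, with a wide range allowed for an unseen effect. The estimate for compound 3 in this assay is 20000 nM, between 5000 nM and 80000 nM.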

Compound 3, concentration for 50% growth inhibition: 22000 nM
Compound 3: middle estimate off by 1.1-fold (0.04 log units), on the low side; the measured number falls inside the stated range.
By their numbers in this assay, from the lowest: compounds 1, 2 and 3 (each within the scatter of the next).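

In this assay, going by these compounds alone, replacing cyclohexyl with 4,4-dibromobut-3-en-1-yl gives a 1.1-fold higher number from compound 2 to compound 3 (0.04 log units; within the scatter), the first measured exchange at this saturated ring carbon next to the ring oxygen. The result shows that this position can carry an open chain with a double bond and bromine atoms instead of a six-membered carbon ring while the number stays within the scatter, something the earlier methyl step, made elsewhere on the shared core, could not show. Nothing available explains why these two quite different groups give numbers within the scatter of each other.

One exchange cannot show whether the number at this position is insensitive to most groups or whether these two simply happen to read alike. From the compounds shown here alone, it remains open whether an amine, a carboxylic acid, a phenyl ring or a longer chain at this position would give a step beyond the scatter, and so whether any group placed here can make the shared core a stronger inhibitor of growth.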